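From 4-methylphenyl to phenyl on compound 2

The source may hold more compounds than are shown below. What is called first, only, known or untested is meant among the compounds shown, and "the series" means these compounds.

Compound 1 `CC1Cn2c(nc([N+](=O)[O-])c2-c2ccc(C=O)cc2)O1` gives 255000 nM
Compound 2 `Cc1ccc(C#Cc2c([N+](=O)[O-])nc3n2CC(C)O3)cc1` gives 5470 nM

In an ADME assay on CHO cells (Cricetulus griseus) for cytotoxicity, read by MTT assay, with a stated time of 24 h (on this read-out higher numbers stand for lower toxicity in this test and lower numbers for higher toxicity in this test), compound 2 (5470 nM) holds the lower of the two numbers, and compound 1 stands higher, beyond the scatter. Compound 3 (`CC1Cn2c(nc([N+](=O)[O-])c2C#Cc2ccccc2)O1`) has hydrogen in place of methyl on an aromatic carbon. For the measured compounds named here, no measured pair shows this change, so nothing beyond the scatter is expected in this assay, and the estimated step is small (a 1.2-fold higher number from compound 2 to compound 3 (0.07 log units; within the scatter)). For compound 3 the estimated value is 6500 nM (expected range 2200 nM to 20000 nM).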

Compound 3, half-maximal cytotoxic concentration: 3540 nM
Compound 3: the middle estimate sits 1.8-fold (0.26 log units) above what was measured, and the stated range covers the measured number.
By their numbers in this assay, from the lowest: compounds 3 and 2 (each within the scatter of the next); then compound 1.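

In this assay, for the compounds shown here, the step of a 1.5-fold lower number from compound 2 to compound 3 (0.19 log units; within the scatter) gives the first direct reading of this change, and it shows that hydrogen in place of methyl on an aromatic carbon, para to a large group, leaves the two compounds within the scatter of each other. At this place on the phenyl ring, then, the methyl group makes no readable difference in this test. Nothing at hand bears on this result. The compounds shown leave open whether an amine, a carboxylic acid or a longer chain at the same place would give a number beyond the scatter.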